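Benzofuranyl for iodo on the core of compound 1

The source may hold more compounds than are shown below. What is called first, only, known or untested is meant among the compounds shown, and "the series" means these compounds.

Measured so far:
compound 1 `COc1ncnc2c1c(I)cn2[C@@H]1O[C@H](CO)[C@@H](O)[C@H]1O` — 91000 nM
compound 2 `Cc1nc(N)c2c(-c3cc4ccccc4o3)cn([C@@H]3O[C@H](CO)[C@@H](O)[C@H]3O)c2n1` — > 100000 nM

In an ADME assay on BJ cells (Homo sapiens), read by MTT assay, with a stated time of 72 h (a higher number here means a weaker inhibitor, a lower number a stronger inhibitor), compound 1 gives 91000 nM. Among the compounds with values here, this is the only number among the values shown. Compound 2 sits at the limit of this assay, > 100000 nM, which is a limit and not a number (the limit of > 100000 nM in this assay, at which 1 of the 2 values shown sits). Within the data shown here, no step between two measured compounds is available, so the two values say only that compound 1 is a weak inhibitor and compound 2 is not resolved.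

Compound 3 `COc1ncnc2c1c(-c1cc3ccccc3o1)cn2[C@@H]1O[C@H](CO)[C@@H](O)[C@H]1O` is the unmeasured analogue of compound 1. Its change from compound 1 is 1-benzofuran-2-yl in place of iodo on an aromatic carbon. The group entering is the same one carried by compound 2, on a different core, and there compound 2 reaches only the limit. With compound 1 already weak at 91000 nM, no gain beyond the scatter is expected. A move toward weaker inhibition is the more likely outcome.

The step from compound 1 to compound 3 in this assay is expected to be a 1.2-fold higher number from compound 1 to compound 3 (0.08 log units; within the scatter), roughly within the scatter or a little weaker. Compound 3 is therefore expected at 110000 nM, in the range 40000 nM to 300000 nM, with a fair chance that only a limit is reported.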

Compound 3, half-maximal inhibitory concentration: 22400 nM
The estimate for compound 3 lay 4.9-fold (0.69 log units) above the measured number; the measured number lies below the stated range.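

In this assay, 1-benzofuran-2-yl in place of iodo on the shared core gives a 4.1-fold lower number from compound 1 to compound 3 (0.61 log units; beyond the scatter), so this aromatic carbon accepts the much larger two-ring group, and the number moves toward stronger inhibition, though only modestly. The earlier compounds shown here gave no reading of this group at this position, since compound 2 carries it on a different core and its value is a limit, not a number: the limit of > 100000 nM in this assay, at which 1 of the 3 values shown sits. With both compound 1 and compound 3 giving numbers on one core, the change can now be read directly, and on this core the group does not push the value to the limit.

A single step at one position cannot separate what in the entering group matters, whether its two aromatic rings, its ring oxygen or simply its size. Still open, as far as these compounds go, are how a phenyl group, an amine or a carboxylic acid on this carbon would read in this assay, and whether the step carries over to the core of compound 2.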